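The source may hold more compounds than are shown below. What is called first, only, known or untested is meant among the compounds shown, and "the series" means these compounds.

Measured so far, in a functional assay on HEK293 cells for agonist activity at Bombesin receptor subtype-3 (Homo sapiens), read by luminescence and calcium flux, with a stated time of 10 min; on this read-out higher numbers stand for an effect only at larger amounts of compound and lower numbers for an effect already at smaller amounts:
- compound 1 `CCC(C)(C)Cc1c[nH]c(CCc2ccc(-n3ccnn3)cc2)n1`: 93 nM
- compound 2 `CCC(C)(C)Cc1c[nH]c(CCc2ccc(-c3ccc(F)cn3)cc2)n1`: 97 nM

Compound 2 and compound 1 lie within the usual scatter of each other, so the two are not distinguishable on this read-out. For the measured compounds named here, the only measured step, a 1.0-fold higher number from compound 1 to compound 2 (0.02 log units; within the scatter), exchanged one aromatic group at the end of the molecule for another without any change beyond the scatter.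

Compound 3 `CCC(C)(C)Cc1c[nH]c(CCc2ccc(-c3cccc(N)n3)cc2)n1` differs from compound 2 in that same place: 6-aminopyridin-2-yl in place of 5-fluoropyridin-2-yl on an aromatic carbon. The step from compound 1 to compound 2 bears on this, since it also replaced the group at this position, and it did not move the number. On that basis the expected step of a 1.1-fold higher number from compound 2 to compound 3 (0.05 log units; within the scatter) is none beyond the scatter, though the new group brings a hydrogen-bond donor for which no measured comparison exists. Compound 3 is therefore estimated at 110 nM in this assay, with a range from 35 nM to 350 nM.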

Compound 3, half-maximal effective concentration: 97 nM
Beside the measured number, compound 3's estimate is 1.1-fold (0.05 log units) above it; measured number inside the range.
By their numbers in this assay, from the lowest: compounds 1, 2 and 3 (each within the scatter of the next).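

In this assay, putting 6-aminopyridin-2-yl in place of 5-fluoropyridin-2-yl gave no change at the digits printed from compound 2 to compound 3 (within the scatter), so this position, on an aromatic carbon para to a large group, tolerates a group carrying a hydrogen-bond donor, which neither earlier group has. Set against 1H-1,2,3-triazol-1-yl, the same group gave a 1.0-fold higher number from compound 1 to compound 3 (0.02 log units; within the scatter), so three different aromatic groups at this position now lie within the scatter of one another. Nothing available here explains why the number stays so steady across these groups.

As far as these compounds go, all three groups at this position are aromatic rings, so it remains open whether a carboxylic acid, a simple amine or a plain hydrogen there would keep the number. From the compounds shown here alone, it is also open whether the same tolerance would hold for a larger two-ring group such as quinolinyl.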